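The source may hold more compounds than are shown below. What is called first, only, known or untested is meant among the compounds shown, and "the series" means these compounds.

In a functional assay on MCF7 cells (Homo sapiens) for cytotoxicity, read by sulforhodamine B assay, with a stated time of 48 h (on this read-out lower numbers stand for stronger inhibition of growth and higher numbers for weaker inhibition of growth), compound 1, `O=C1C(=O)N(CN2CCN(c3ccnc4cc(Cl)ccc34)CC2)c2ccccc21`, gives 48300 nM. Among the measured compounds shown here, compound 2, `NC(=S)N/N=C1/C(=O)N(CN2CCN(c3ccnc4cc(Cl)ccc34)CC2)c2cccc(Cl)c21`, gives 57500 nM in this assay, a number that lies within the usual scatter of the one measured for compound 1. Compound 3, `NC(=S)N/N=C1/C(=O)N(CN2CCN(c3ccnc4cc(Cl)ccc34)CC2)c2ccccc21`, awaits measurement. It differs from compound 2 by hydrogen in place of chloro on an aromatic carbon. For the measured compounds named here, no pair measured so far shows what the loss of a chloro at this place does, so the expected step in this assay from compound 2 to compound 3 is a 1.0-fold lower number from compound 2 to compound 3 (0.02 log units; within the scatter), none beyond the scatter. Compound 3 is therefore expected to give about 55000 nM in this assay, within a range from 20000 nM to 150000 nM.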

Compound 3, concentration for 50% growth inhibition: 23000 nM
Estimate against measurement, compound 3: 2.4-fold (0.38 log units) above, and the stated range covers the measured number.
By their numbers in this assay, from the lowest: compound 3; then compounds 1 and 2 (each within the scatter of the next).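

In this assay, replacing the chloro with hydrogen on this aromatic carbon, ortho to a fused ring and meta to a fused ring, gives a 2.5-fold lower number from compound 2 to compound 3 (0.40 log units; beyond the scatter), a modest step but one beyond the scatter. Among the compounds shown here, this pair is the first to show that the chloro at this place matters in this assay, and that the compound carrying hydrogen has the lower number. Nothing measured here accounts for the step. On these data alone, whether a fluoro, a methyl or a methoxy group on this carbon would give a number nearer that of compound 2 or compound 3 remains open.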